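The compounds below may be only part of what the source reports. "The series", "measured", "known", "first", "only" and "open" are said of these compounds alone.

Compound 1, `Cc1cccc(Nc2nc(C)c(C(=O)/C=C/c3ccccc3Cl)s2)c1`: 22200 nM in a functional assay on PC-3 cells (Homo sapiens) for cytotoxicity, read by MTT assay; a higher number here means a weaker inhibitor, a lower number a stronger inhibitor. Compound 2, `Cc1nc(Nc2ccccc2)sc1C(=O)/C=C/c1ccccc1`: > 25000 nM in this assay.

Compound 2 stands at a limit in this assay. Its result, > 25000 nM, is a limit of the assay and not a number; this is the limit of > 25000 nM in this assay, at which 1 of the 2 values shown sits.

Compound 3, `Cc1nc(Nc2ccccc2)sc1C(=O)/C=C/c1ccccc1Cl`, differs from compound 2 in one place: chloro in place of hydrogen on an aromatic carbon. Going by the values given here, the same chloro is also present in compound 1, which in this assay gives 22200 nM while carrying a methyl elsewhere, so no measured pair shows this change on its own. Because compound 1 with the chloro gives 22200 nM, the step from compound 2 to compound 3 is expected to be a number no higher from compound 2 to compound 3 (the limit leaves the size open), which is nothing beyond the usual scatter. Compound 3 is therefore expected to give 25000 nM in this assay, within a range from 10000 nM to 60000 nM, and it may well again be reported only as a limit.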

Compound 3, half-maximal inhibitory concentration: > 25000 nM
Compound 3 ended at the assay's limit; the forecaster's own chance of this, stated with the estimate: 55%; the middle value lies on the limit itself.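

Compound 3 gives > 25000 nM in this assay, which is a limit of the assay and not a number, and it shares that limit with compound 2: the limit of > 25000 nM in this assay, at which 2 of the 3 values shown sit. The change from phenyl to 2-chlorophenyl therefore does not bring the compound to a measured number, and the step it makes cannot be read. Hydrogen in place of methyl on an aromatic carbon gives an at least 1.1-fold higher number from compound 1 to compound 3 (0.05 log units; that floor lies within the scatter), so the compounds shown do not establish that this methyl matters.

The compounds shown leave open whether the chloro has any effect on its own, since no measured pair isolates it. They also leave open whether a different group on this ring, such as a methoxy group or an amine, would give a measured number in this assay.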